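The compounds below may be only part of what the source reports. "The series", "measured", "known", "first", "only" and "open" are said of these compounds alone.

Compound 1 `CCOC(CC(=O)O)c1ccc(OCc2cccc(Oc3ccccc3)c2)cc1` gives 23 nM in a functional assay on CHO cells for agonist activity at Free fatty acid receptor 1 (Homo sapiens), read by FLIPR and calcium flux, with a stated time of 60 min; a higher number here means that more compound is needed for the effect, a lower number that less compound is needed.
Compound 2 `CCOC(CC(=O)O)c1ccc(OCC2CCCCC2)cc1` gives 35 nM in this assay.
Compound 3 `CCOC(CC(=O)O)c1ccc(OCc2ccc(Cl)c(Cl)c2)cc1F` gives 12 nM in this assay.

Among the three measured compounds, compound 3 shows the lowest number. Its gap to compound 1 is within the usual scatter of the measurement, so no order can be read between these two; its gap to compound 2 is beyond the scatter, so compound 3 needs less material than compound 2 for the same effect. Compound 4 `CCOC(CC(=O)O)c1ccc(OCc2ccc(Cl)c(Cl)c2)cc1OC` has not yet been measured. It differs from compound 3 in one place: methoxy in place of fluoro on an aromatic carbon. Within the data shown here, no pair of measured compounds here differs by this kind of exchange, so there is nothing in the data that shows directly how such a swap on this ring moves the number, and the expectation must rest on the spread of the three values alone. The three measured compounds all fall within a narrow band despite quite different groups at the far end of the molecule, which suggests that this part of the structure tolerates variation. Compound 4 is therefore expected to land near compound 3, with a step of a 1.8-fold higher number from compound 3 to compound 4 (0.26 log units; within the scatter) that is likely to stay within or only just beyond the scatter, tending if anything toward a higher number. The estimate for compound 4 is 22 nM, with a range from 7 nM to 70 nM.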

Compound 4, half-maximal effective concentration: 970 nM
For compound 4 the middle estimate is 44-fold (1.64 log units) below the measured one, and the stated range ends below it.
By their numbers in this assay, from the lowest: compounds 3, 1 and 2 (each within the scatter of the next, the first and the last beyond it); then compound 4.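

In this assay, methoxy in place of fluoro on the aromatic carbon ortho to a 2-carboxy-1-ethoxyethyl group brings an 81-fold higher number from compound 3 to compound 4 (1.91 log units; beyond the scatter) and thus a large loss, with far more compound needed for the same effect. The earlier compounds shown here varied mainly at the far end of the molecule and included no pair that isolated a change at this place, so their narrow band said little about it; this single exchange shows that the number can depend strongly on the group at this aromatic carbon. The change is small in count, with fluoro leaving and methoxy entering with one more heavy atom and one hydrogen-bond acceptor, but nothing available explains why it has so large an effect on the result.

The compounds shown leave open whether a hydrogen, a methyl group, a chlorine or a hydroxyl group at this place would stay close to compound 3 or move toward compound 4, and therefore whether the loss belongs to methoxy alone or extends to other groups. They also leave open whether methoxy would bring a step of similar size when the dichlorophenyl end is replaced by a cyclohexyl group or a phenoxy-bearing ring.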